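The compounds below may be only part of what the source reports. "The series", "measured", "known", "first", "only" and "open" are said of these compounds alone.

Compound 1, `Cc1cccc(/C=N/NC(N)=S)c1`: in a functional assay on B16 cells (Mus musculus) for inhibition, tested at 10 uM (on this read-out higher numbers stand for more inhibition at the one concentration tested (going by the name of the read-out) and lower numbers for less inhibition), compound 1 gives > 100%, which is a limit of the assay and not a number.
Compound 2, `NC(=S)N/N=C/c1cccc(Cl)c1`: in this assay compound 2 gives > 100%, again a limit of the assay.
Compound 3, `Cc1ccccc1/C=N/NC(N)=S`: in this assay compound 3 gives > 100%, also a limit of the assay.

For the measured compounds named here, compound 3 thus stands at the upper edge of what this assay reports, the same place where every value so far has landed, (the limit of > 100% in this assay, at which 3 of the 3 values shown sit). The unmeasured compound 4, `NC(=S)N/N=C/c1ccccc1Cl`, differs from compound 3 in one place: chloro in place of methyl on an aromatic carbon.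

Going by the values given here, the one measured step that bears on this change is the same exchange made on compound 1, a step that the two limits leave unreadable from compound 1 to compound 2. Because both ends of that step are limits, its size cannot be read, and it gives no direction for the new step. With compound 3 already at the limit, no movement beyond the scatter is expected from compound 3 to compound 4, a number no higher from compound 3 to compound 4 (the limit leaves the size open), as an estimate. Compound 4 is therefore estimated at 100%, in a range from 85% to 100%, most likely reported again as a limit.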

Compound 4, a percentage reported as inhibition, at one concentration (the size of the read-out at that concentration, not a potency): > 100%
Compound 4: a limit, no number; the forecaster's own chance of this, stated with the estimate: 80%; the middle value sits exactly at the limit.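

Compound 3 and compound 4 both stand at a limit of this assay, not at a number, so the step between them cannot be read. The compounds shown leave open how chloro and methyl compare at this place, since the read-out gives only its limit: the limit of > 100% in this assay, at which 4 of the 4 values shown sit.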